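The compounds below may be only part of what the source reports. "The series", "measured", "known", "first", "only" and "open" are said of these compounds alone.

Measured in an assay on HEK293 cells for displacement of a labelled ligand from adenosine receptor A2b (Homo sapiens), read by scintillation counting, with a stated time of 30 min, tested at 10 uM; a lower number here means less inhibition, a higher number more inhibition at the concentration tested (going by the name of the read-out):
- compound 1 `COc1cccc2cc(C(=O)NC3CCCCC3)c(=N)oc12`: > 70%
- compound 2 `COc1cccc2cc(C(=O)NC3CCCC3)c(=N)oc12`: 47%
- compound 3 `COc1cccc2cc(C(=O)NCCCCCO)c(=N)oc12`: > 70%

The value of compound 1 is a limit of this assay, not a number. The value of compound 3 is likewise a limit, so compound 3 stands at the top of what this assay reports, a position it shares as described by the limit of > 70% in this assay, at which 2 of the 3 values shown sit. Between the measured compounds, the step of a number at least 23 percentage points lower from compound 1 to compound 2 (beyond the scatter) and the step of a number at least 23 percentage points higher from compound 2 to compound 3 (beyond the scatter) are both beyond the scatter, while the step that the two limits leave unreadable from compound 1 to compound 3 cannot be sized from two limits.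

Compound 4 `COc1cccc2cc(C(=O)NC(CO)(CO)CO)c(=N)oc12` differs from compound 3 only at the amide-type nitrogen: 2-hydroxy-1,1-bis(hydroxymethyl)ethyl in place of 5-hydroxypentyl on an amide-type nitrogen. The measured steps bearing on this position are a number at least 23 percentage points higher from compound 2 to compound 3 (beyond the scatter) and a step that the two limits leave unreadable from compound 1 to compound 3; they show that this nitrogen substituent can move this assay by a modest amount, but none of them covers a group like 2-hydroxy-1,1-bis(hydroxymethyl)ethyl. Compound 4 is therefore expected to show a downward step of a number at least 25 percentage points lower from compound 3 to compound 4 (beyond the scatter). The estimate for compound 4 in this assay is 45%, within 20% to 70%.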

Compound 4, a percentage reported as inhibition, at one concentration (the size of the read-out at that concentration, not a potency): 28%
Estimate against measurement, compound 4: 17 percentage points above; measured number inside the range.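

In this assay, going by these compounds alone, the step to 2-hydroxy-1,1-bis(hydroxymethyl)ethyl on the amide-type nitrogen is the first to show that a hydroxyl-bearing group there need not keep the reading high, with a number at least 42 percentage points lower from compound 3 to compound 4 (beyond the scatter). The same group also falls short of both rings, with a number at least 42 percentage points lower from compound 1 to compound 4 (beyond the scatter) and with a number 19 percentage points lower from compound 2 to compound 4 (beyond the scatter), so compound 4 gives the lowest reading of the four compounds. The two large steps start from limits of the assay, not from numbers: the limit of > 70% in this assay, at which 2 of the 4 values shown sit.

The compounds shown leave open whether the fall goes with the number of hydroxyl groups or with the branching of the group, which tert-butyl or 2-hydroxyethyl on the same nitrogen could begin to separate. They also leave open how a pentyl chain would read with an amine or a carboxylic acid in place of its hydroxyl.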